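Sulfone series at metabotropic glutamate receptor 5: compound 4 outlook

The source may report more compounds than this note shows. Statements on the series, on what has been measured and on what is new or still open speak of the compounds shown alone.

Measured so far:
compound 1 `COc1ccc(S(=O)(=O)c2cnc3c(F)cccc3c2N2CCC(C)CC2)cc1` — 67%
compound 2 `O=S(=O)(c1ccccc1)c1cnc2ccccc2c1N1CCCCCC1` — 79.9%
compound 3 `CC1CCN(c2c(S(=O)(=O)c3ccc(F)c(F)c3)cnc3cc(F)ccc23)CC1` — 94%

All three were run in an assay on isolated protein for displacement of a labelled ligand from metabotropic glutamate receptor 5 (Homo sapiens), with a stated time of 60 min, tested at 1 uM; a higher number here means more inhibition at the concentration tested (going by the name of the read-out), a lower number less inhibition. Among the three, compound 1 stands lowest. Compound 2 sits higher by a margin beyond the scatter, and compound 3 sits higher still, also beyond the scatter. Among the measured compounds shown here, no pair of these three differs in only one place, so no single step can be read off between them; what the numbers show is only that compound 1 gives the smallest inhibition of the set.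

The next compound, compound 4 `CC1CCN(c2c(S(=O)(=O)c3ccc(C#N)cc3)cnc3c(F)cccc23)CC1`, differs from compound 1 in one place: cyano in place of methoxy on an aromatic carbon. Cut one bond further out, the change reads 4-methoxyphenyl to 4-cyanophenyl, placed para to a large group.

For the measured compounds named here, no measured step informs this change directly. Going by the values given here, the two compounds without a methoxy group, compound 2 and compound 3, both gave higher numbers than compound 1, which is the only guide. The step from compound 1 to compound 4 is therefore expected to be upward, about a number 11 percentage points higher from compound 1 to compound 4 (beyond the scatter), though a result within the scatter would not surprise. Compound 4 is estimated at 78%, with a range of 60% to 93%.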

Compound 4, a percentage reported as inhibition, at one concentration (the size of the read-out at that concentration, not a potency): 86%
The estimate for compound 4 lay 8 percentage points below the measured number, and the stated range covers the measured number.
By their numbers in this assay, from the lowest: compound 1; then compounds 2, 4 and 3 (each within the scatter of the next, the first and the last beyond it).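

In this assay, among the compounds shown here, cyano in place of methoxy on an aromatic carbon, para to a large group, gives a number 19 percentage points higher from compound 1 to compound 4 (beyond the scatter), the first step in this set that can be read at a single place, and it shows that the read-out responds to the group at this position on an otherwise unchanged structure. The two groups match in heavy-atom count and in hydrogen-bond donor and acceptor counts, so those counts do not separate 4-methoxyphenyl from 4-cyanophenyl here, though the triple bond is one listed difference between them. No measurement at hand accounts for the step, so it stands as an observation without a cause.

A single pair cannot show whether the gain belongs to the arrival of cyano or to the departure of methoxy; a hydrogen, a chlorine, a trifluoromethyl group or a carboxylic acid on the same carbon of the core of compound 1 would separate the two readings. From the compounds shown here alone, whether the same change gives a step of like size on the structures of compound 2 or compound 3 also remains open.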